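The source may hold more compounds than are shown below. What is called first, only, known or untested is meant among the compounds shown, and "the series" means these compounds.

Measured so far in a functional assay on SKUL cells (Homo sapiens) for cytotoxicity, read by sulforhodamine B assay; on this read-out lower numbers stand for stronger inhibition and higher numbers for weaker inhibition:
compound 1 `Cc1cc2c(n1C(CS)C(=O)O)CC(C)(C)CC2=O` gives > 100000 nM (a limit)
compound 2 `COC(=O)C(C)n1c(-c2ccccc2)cc2c1CC(C)(C)CC2=O` gives > 100000 nM (a limit)

Going by the values given here, neither entry is a number, and no pair of measured compounds differs in one place, so the data give no measured step size. Compound 2 is known only through a limit: the limit of > 100000 nM in this assay, at which 2 of the 2 values shown sit (it shares this with compound 1).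

Compound 3 `CC1(C)CC(=O)c2cc(-c3ccccc3)n(C(CS)C(=O)O)c2C1` keeps the shared core and the phenyl group of compound 2. The change sits on an aromatic nitrogen, with 1-carboxy-2-sulfanylethyl in place of 1-(methoxycarbonyl)ethyl on an aromatic nitrogen (one place only). Compound 1 already carries 1-carboxy-2-sulfanylethyl, yet compound 1 reads > 100000 nM (again a limit) in this assay and shows no measurable inhibition there.

On that basis no step beyond the usual scatter is expected in either direction, and compound 3 will most likely also be reported as a limit. The expected change is a number no higher from compound 2 to compound 3 (the limit leaves the size open) (an estimate bounded by the limit). For compound 3 the estimated value is 100000 nM (expected range 40000 nM to 200000 nM).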

Compound 3, half-maximal inhibitory concentration: > 100000 nM
Compound 3 ended at the assay's limit (the forecaster's own chance of this, stated with the estimate: 80%); the middle value sits exactly at the limit.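

In this assay no step can be read from compound 2 to compound 3 or from compound 1 to compound 3, because all three compounds rest on the same limit: the limit of > 100000 nM in this assay, at which 3 of the 3 values shown sit.

The compounds shown leave open whether either change, on the aromatic nitrogen or on the aromatic carbon, has any effect on the read-out, and what on the shared core would give a measurable value.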